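Acetyl to isopropyl on a side chain: compound 3 expected

The source may hold more compounds than are shown below. What is called first, only, known or untested is meant among the compounds shown, and "the series" means these compounds.

Measured so far:
compound 1, `CC(=O)Cn1nnnc1Cc1ccc(-c2ccccc2)cc1`, gives > 50000 nM, a limit of the assay.
compound 2, `CC(=O)Cn1nnc(Cc2ccc(-c3ccccc3)cc2)n1`, gives > 50000 nM, also a limit of the assay.

In an assay for inhibition of Fatty-acid amide hydrolase 1 (Rattus norvegicus) (a higher number here means a weaker inhibitor, a lower number a stronger inhibitor), compound 2 thus stands only at a limit, and no number is known for it. The same holds for compound 1, so that the limit of > 50000 nM in this assay, at which 2 of the 2 values shown sit, describes both values shown. Compound 3, `CC(C)Cn1nnc(Cc2ccc(-c3ccccc3)cc2)n1`, differs from compound 2 by isopropyl in place of acetyl on a saturated chain carbon bound to an aromatic nitrogen. Since both measured values sit at a limit, no step size between measured compounds can be stated. Compound 3 is expected to remain near that limit, at an estimated 50000 nM with a range from 15000 nM to 100000 nM. The expected step of a number no higher from compound 2 to compound 3 (the limit leaves the size open) is therefore none beyond the scatter.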

Compound 3, half-maximal inhibitory concentration: > 50000 nM
Compound 3 ended at the assay's limit; the forecaster's own chance of this, stated with the estimate: 80%; the middle value lies on the limit itself.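

Among the compounds shown here, compound 2 and compound 3 both sit at a limit, so no step between them can be read: the limit of > 50000 nM in this assay, at which 3 of the 3 values shown sit. The compounds shown leave open how strongly any of them inhibits, and whether isopropyl in place of acetyl changes anything.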